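Swapping the amide tail of a KAT2B inhibitor

The source may hold more compounds than are shown below. What is called first, only, known or untested is meant among the compounds shown, and "the series" means these compounds.

Of the compounds shown here, two have been tested in an assay on isolated protein for inhibition of histone acetyltransferase KAT2B (Homo sapiens), read by fluorescence, with a stated time of 10 min; a higher number here means a weaker inhibitor, a lower number a stronger inhibitor. Compound 1 `COCCNC(=O)Cn1sc2ccccc2c1=O` gives 11800 nM and compound 2 `Cc1ccc(-c2csc(-n3sc4ccccc4c3=O)n2)cc1` gives 5820 nM; compound 1 therefore stands at the higher of the two numbers, and its gap to compound 2 goes beyond the usual scatter. Compound 3 `O=C(Cn1sc2ccccc2c1=O)NCc1ccccn1` keeps the core of compound 1 and changes only the tail on the amide: pyridin-2-yl in place of methoxymethyl on a saturated chain carbon bound to an amide-type nitrogen. Among the measured compounds shown here, no measured pair in this set shows such a change, so the size of the step cannot be read from the data. Compound 2 carries an aromatic ring and gives a lower number than compound 1, which is the only hint available, and it is a weak one. The step from compound 1 to compound 3 is expected to be small, a 1.5-fold lower number from compound 1 to compound 3 (0.17 log units; within the scatter), toward a lower number but close to the scatter. Compound 3 is estimated at 8000 nM, within a range from 3000 nM to 25000 nM.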

Compound 3, half-maximal inhibitory concentration: 15100 nM
The estimate for compound 3 lay 1.9-fold (0.28 log units) below the measured number; low and high end bracket the measured number.
By their numbers in this assay, from the lowest: compound 2; then compounds 1 and 3 (each within the scatter of the next).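

In this assay, putting pyridin-2-yl in place of methoxymethyl on a saturated chain carbon bound to an amide-type nitrogen gives a 1.3-fold higher number from compound 1 to compound 3 (0.11 log units; within the scatter) and so leaves the two tails indistinguishable in this measurement. Among the compounds shown here, this is the first measured step at this position, and it shows that a six-membered aromatic ring can take the place of an open-chain ether end without the number moving beyond the scatter. No evidence here bears on this result.

With only these two tails on the amide, the data cannot say whether the ring nitrogen matters, which a plain phenyl in place of pyridin-2-yl would test. They also leave open whether an amine, a carboxylic acid or a longer chain at this position would move the number beyond the scatter.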